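A few compounds are considered here, and "the series" means these few. Any claim that something is new, unique, unknown or untested is made for them only; others in the source may bear on it.

Compound 1 `O=C(CN1CCN(c2cc3c(cc2F)c(=O)c(C(=O)O)cn3C2CC2)CC1)Nc1ccc(C(=O)/C=C/c2ccccc2Cl)cc1`: 2.12 ug/mL
Compound 2 `COc1ccc(/C=C/C(=O)c2ccc(NC(=O)CN3CCN(c4cc5c(cc4F)c(=O)c(C(=O)O)cn5C4CC4)CC3)cc2)cc1`: 2.42 ug/mL

Both were run in a physicochemical assay for solubility, at pH 7.8; on this read-out higher numbers stand for higher solubility and lower numbers for lower solubility. Among these two numbers compound 2 stands highest, but its only neighbour, compound 1, sits within the scatter of it, so no order can be read between them; the single step, a 1.1-fold higher number from compound 1 to compound 2 (0.06 log units; within the scatter), did not move this assay beyond its scatter.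

Compound 3 `COc1ccc(/C=C/C(=O)c2ccc(NC(=O)CN3CCN(c4cc5c(cc4F)c(=O)c(C(=O)O)cn5C4CC4)CC3)cc2)cc1OC` has not yet been measured in this assay. It differs from compound 2 by methoxy in place of hydrogen on an aromatic carbon. Among the measured compounds shown here, no measured step covers this particular change; the one step available concerns a different exchange on the same chain and was flat. Nothing in the series gives grounds for a step beyond the scatter in either direction, so compound 3 is expected to land close to its parent. For compound 3 this means an expected step of a 1.1-fold lower number from compound 2 to compound 3 (0.04 log units; within the scatter). The estimate for compound 3 is 2.2 ug/mL, with a range from 0.9 ug/mL to 5.5 ug/mL.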

Compound 3, solubility: 0.68 ug/mL
The estimate for compound 3 lay 3.2-fold (0.51 log units) above the measured number; the whole stated range lies above it.
By their numbers in this assay, from the lowest: compound 3; then compounds 1 and 2 (each within the scatter of the next).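

In this assay, among the compounds shown here, methoxy in place of hydrogen on this aromatic carbon, ortho to a methoxy group and meta to a large group, gives the first step beyond the scatter: a 3.6-fold lower number from compound 2 to compound 3 (0.55 log units; beyond the scatter). The 3,4-dimethoxyphenyl group also separates from 2-chlorophenyl, with a 3.1-fold lower number from compound 1 to compound 3 (0.49 log units; beyond the scatter), whereas 4-methoxyphenyl in place of 2-chlorophenyl stayed within the scatter, so this ring does not respond flatly to every exchange. No measurement at hand bears on the reason for the lower number.

Still open, on these data alone, is whether the lower number is tied to methoxy itself or would follow any group entering at this carbon. A hydroxy group, an amine or a longer ether chain such as ethoxy at the same place would test this in this assay.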